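Changing the aryl group on the ring nitrogen of compound 3

This account rests on a few compounds, and the source may have more. Where it says the series, first, only, none or still open, it means among the compounds named here.

Three compounds of this series share one core. In a functional assay on U-87MG ATCC cells for antiproliferative activity against U-87 MG (Homo sapiens), read by MTT assay, with a stated time of 72 h (a lower number here means a stronger inhibitor, a higher number a weaker inhibitor), compound 1 `O=C(Nc1ccc(Oc2ccnc3[nH]ccc23)cc1)c1cc2cccnc2n(-c2ccc(F)c(Cl)c2)c1=O` gives "not determined" (no result reported) and compound 2 `Cn1ccc2c(Oc3ccc(NC(=O)c4cc5cccnc5n(-c5ccc(Br)cc5)c4=O)cc3)ccnc21` gives "not determined" (no result reported); for both, no value was reported. Going by the values given here, compound 3 `COc1ccc(-n2c(=O)c(C(=O)Nc3ccc(Oc4ccnc5c4ccn5C)cc3)cc3cccnc32)cc1` is therefore the only member with a number: in this assay compound 3 gives 5150 nM, and with no other figure beside it, it stands alone rather than high or low within the set.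

Compound 4 `Cn1ccc2c(Oc3ccc(NC(=O)c4cc5cccnc5n(-c5ccc(F)c(Cl)c5)c4=O)cc3)ccnc21` differs from compound 3 in one place: 3-chloro-4-fluorophenyl in place of 4-methoxyphenyl on an aromatic nitrogen. Among the compounds with values here, no pair of measured compounds traces this change, so nothing measured here tells how large the step will be. The expectation is a modest move toward stronger inhibition, a 2.1-fold lower number from compound 3 to compound 4 (0.31 log units; beyond the scatter), though a step within the scatter would not surprise. Compound 4 is thus estimated at 2500 nM, with a plausible range from 600 nM to 10000 nM, resting solely on compound 3 and the single substitution.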

Compound 4, half-maximal inhibitory concentration: 2350 nM
The estimate for compound 4 lay 1.1-fold (0.03 log units) above the measured number; measured number inside the range.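

This result gives the series its first measured step at this position: in this assay, putting 3-chloro-4-fluorophenyl in place of 4-methoxyphenyl on the aromatic nitrogen gives a 2.2-fold lower number from compound 3 to compound 4 (0.34 log units; beyond the scatter). The number at this position therefore responds to the aryl group, and it moves toward stronger inhibition with the heavy-atom count unchanged, as the one hydrogen-bond acceptor of the leaving group gives way to fluorine and chlorine. Nothing available explains this shift, so the step stands as an observation only.

Going by these compounds, whether the chlorine, the fluorine or the loss of the methoxy group carries the change stays open, as all three change together here. Also open, on these data alone, is how the position responds to a simple methyl group, or to an aryl group carrying an amine or a carboxylic acid.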